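A ring gives way to a chain in compound 4

The source may report more compounds than this note shows. Statements on the series, on what has been measured and on what is new or still open speak of the compounds shown alone.

Measured in a physicochemical assay for solubility, in phosphate buffer, measured as kinetic solubility, at pH 7.4; a higher number here means a more soluble compound, a lower number a less soluble compound (every value here is a limit):
- compound 1 `Cc1oc(-c2c(Cl)cccc2Cl)nc1CN1CCC(C(=O)NCCCN2C[C@H](C)C[C@H](C)C2)CC1` gives > 77 ug/mL
- compound 2 `COc1cccc(Br)c1-c1nc(CN2CCC(C(=O)NCCCN3C[C@H](C)C[C@H](C)C3)CC2)c(C)o1` gives > 83 ug/mL
- compound 3 `COc1ccc(-c2nc(CN3CCC(C(=O)NCCCN4C[C@H](C)C[C@H](C)C4)CC3)c(C)o2)cc1OC` gives > 76 ug/mL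

Compound 3 has only a limit (> 76 ug/mL), as do the other two compounds. Compound 4 (`CCN(CC)CCCCNC(=O)C1CCN(Cc2nc(-c3ccc(OC)c(OC)c3)oc2C)CC1`) differs from compound 3 in one place ((diethylamino)methyl in place of 3,5-dimethylpiperidin-1-yl on a saturated chain carbon, three bonds along the chain from an amide-type nitrogen). The ring is gone, and 3-(3,5-dimethylpiperidin-1-yl)propyl becomes 4-(diethylamino)butyl.

Three measured steps are available (a step that the two limits leave unreadable from compound 1 to compound 2), (a step that the two limits leave unreadable from compound 1 to compound 3) and (a step that the two limits leave unreadable from compound 2 to compound 3). Each swaps a group on an aromatic carbon, so none touches this chain, and none has a readable size. The expectation therefore rests on compound 3 alone, whose limit (> 76 ug/mL) is the only anchor. No step beyond the usual scatter is expected in this assay here. The estimate amounts to an expected at least 1.0-fold lower number from compound 3 to compound 4 (0.02 log units; that floor lies within the scatter) (a reading that may again be only a limit). Compound 4 is expected near 72 ug/mL (estimated range 55 ug/mL to 85 ug/mL).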

Compound 4, solubility: > 72 ug/mL
Compound 4 gave a limit, no number; the forecaster's own chance of this, stated with the estimate: 85%; the middle value lies on the limit itself.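

In this assay compound 4 gives > 72 ug/mL, which is a limit and not a number. Within the data shown here, compound 3 also has only a limit, so no step from compound 3 to compound 4 can be read. The compounds shown leave open how soluble each one actually is, and whether exchanging 3-(3,5-dimethylpiperidin-1-yl)propyl for 4-(diethylamino)butyl changes that at all.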